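A few compounds are considered here, and "the series" means these few. Any claim that something is new, unique, unknown or untested is made for them only; others in the source may bear on it.

Measured so far in an ADME assay on SK-N-BE(2)-M17 cells (Homo sapiens) for cytotoxicity; a higher number here means that more compound is tolerated, a lower number that less compound is tolerated:

- compound 1, `CC1=CC(C)(C)Nc2c(C(=O)N[C@@H](C)/C=C/S(C)(=O)=O)cccc21`: > 25000 nM, which is a limit of this assay and not a number
- compound 2, `COC(=O)/C=C/CNC(=O)c1cccc2c1NC(C)(C)C=C2C`: 18100 nM
- compound 3, `C[C@@H]1CC(C)(C)Nc2c(C(=O)N[C@@H](C)/C=C/S(C)(=O)=O)cccc21`: > 25000 nM, which again is a limit and not a number

Compound 1 and compound 2 share one core and differ only in the group on the amide-type nitrogen: 3-(methoxycarbonyl)prop-2-en-1-yl in place of 1-methyl-3-(methylsulfonyl)prop-2-en-1-yl on an amide-type nitrogen. In this assay this change gives an at least 1.3-fold lower number from compound 1 to compound 2 (0.14 log units; that floor lies within the scatter). Since compound 1 sits at a limit, the true size of the step is open; what is known is summed up in the limit of > 25000 nM in this assay, at which 2 of the 3 values shown sit.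

Compound 3 carries a different core from compound 1, and how the two cores differ is not broken down here. Compound 4, `COC(=O)/C=C/CNC(=O)c1cccc2c1NC(C)(C)C[C@H]2C`, has not yet been measured in this assay. It stands to compound 3 as compound 2 stands to compound 1: 3-(methoxycarbonyl)prop-2-en-1-yl in place of 1-methyl-3-(methylsulfonyl)prop-2-en-1-yl on an amide-type nitrogen. The place of the change, an amide-type nitrogen whose other neighbour is a carbonyl carbon, is the same in both pairs, so this is the same change made on another core.

For compound 4 the expected step is an at least 1.2-fold lower number from compound 3 to compound 4 (0.09 log units; that floor lies within the scatter), resting on the earlier step of an at least 1.3-fold lower number from compound 1 to compound 2 (0.14 log units; that floor lies within the scatter), with the caveat that compound 3 is known only by its limit > 25000 nM. The estimate for compound 4 in this assay is 20000 nM, expected to lie between 10000 nM and 40000 nM.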

Compound 4, half-maximal cytotoxic concentration: 11000 nM
Compound 4: the middle estimate sits 1.8-fold (0.26 log units) above what was measured; the measured number falls inside the stated range.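

In this assay, putting 3-(methoxycarbonyl)prop-2-en-1-yl in place of 1-methyl-3-(methylsulfonyl)prop-2-en-1-yl on the amide-type nitrogen gives an at least 2.2-fold lower number from compound 3 to compound 4 (0.35 log units; beyond the scatter), so on this core less compound is tolerated after the change. As far as these compounds go, compound 3 gives > 25000 nM in this assay, which is a limit and not a number, so this step is known only as a floor and its true size remains unknown. The change lowers the number on both cores, but only the floor on the core of compound 3 clears the scatter, and the two steps cannot be said to match or to differ in size: the same change on two cores in this assay, an at least 1.3-fold lower number (0.14 log units; that floor lies within the scatter) from compound 1 to compound 2 and an at least 2.2-fold lower number (0.35 log units; beyond the scatter) from compound 3 to compound 4; the limit leaves it open whether they differ.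

The swap alters the end of the chain and removes the 1-methyl branch in a single move, so the compounds shown leave open which of the two goes with the lower number, a question that 3-(methylsulfonyl)prop-2-en-1-yl, without the branch, would bear on. They also leave open how a carboxylic acid in place of the methyl ester, or a longer chain, would fare, and how far the values at the top of the range really reach: the limit of > 25000 nM in this assay, at which 2 of the 4 values shown sit.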